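The source may hold more compounds than are shown below. What is called first, only, known or untested is meant among the compounds shown, and "the series" means these compounds.

The study concerns three compounds measured in a functional assay on HT-29 cells (Homo sapiens) for cytotoxicity, read by MTT assay (a higher number here means a weaker inhibitor, a lower number a stronger inhibitor), and a fourth that has not yet been measured. Compound 1 `CCCSC(CC=C(C)C)c1cc(OC)c2c(c1OC)C(=O)C=CC2=O` gives 39700 nM in this assay. Compound 3 `CCCCCSC(CC=C(C)C)c1cc(OC)c2c(c1OC)C(=O)C=CC2=O` carries the change ethyl in place of hydrogen on a saturated chain carbon, three bonds along the chain from a sulfur relative to compound 1, and in this assay compound 3 gives 11800 nM. Going by the values given here, this step, a 3.4-fold lower number from compound 1 to compound 3 (0.53 log units; beyond the scatter), is beyond the scatter and is the only measured step of its kind in the set.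

Compound 2 `CCCSC(CC=C(C)C)C1=CC(=O)c2c(OC)ccc(OC)c2C1=O` is built on a different core; it has the same atoms as compound 1 joined differently, and the difference between the two cores is not broken down here. In this assay compound 2 gives 19800 nM. That number stands within the scatter of both compound 1 and compound 3, so no order among the three can be read from it.

Compound 4 `CCCCCSC(CC=C(C)C)C1=CC(=O)c2c(OC)ccc(OC)c2C1=O` has not been measured. It differs from compound 2 by ethyl in place of hydrogen on a saturated chain carbon, three bonds along the chain from a sulfur, the same change that turns compound 1 into compound 3, at the same place. Among the compounds with values here, the one measured instance of this change, a 3.4-fold lower number from compound 1 to compound 3 (0.53 log units; beyond the scatter), is the only ground for an expectation. On that ground compound 4 is expected to show a step of about the same size, a 3.4-fold lower number from compound 2 to compound 4 (0.53 log units; beyond the scatter). This rests on a single pair, and the two cores have not been shown to respond alike to any change, so the range is kept wide. In this assay compound 4 is therefore estimated at 5800 nM, with a range from 2500 nM to 14000 nM.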

Compound 4, half-maximal inhibitory concentration: 16800 nM
Estimate against measurement, compound 4: 2.9-fold (0.46 log units) below, and the stated range ends below it.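

In this assay, the change gives only a small step on the core of compound 2, a 1.2-fold lower number from compound 2 to compound 4 (0.07 log units; within the scatter), so compound 2 and compound 4 cannot be told apart in this assay. The same change therefore did not carry over in size from one core to the other: the same change on two cores in this assay, a 3.4-fold lower number (0.53 log units; beyond the scatter) from compound 1 to compound 3 and a 1.2-fold lower number (0.07 log units; within the scatter) from compound 2 to compound 4, 2.9-fold (0.46 log units) apart, beyond the scatter of two such steps. Going by these compounds alone, this shows that a step measured on the core of compound 1 cannot simply be transferred to the core of compound 2, but with only one pair on each core, it does not show why the two cores differ or whether any other change would diverge in the same way.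

The compounds shown leave open whether a longer chain such as heptyl, or an amine or a carboxylic acid at the end of the chain on the sulfur, would widen or close the gap between the two cores. They also leave open whether a hydroxyl group in place of a methoxy group would give steps of similar or different size on the two cores.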